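The source may hold more compounds than are shown below. What is called first, only, known or untested is meant among the compounds shown, and "the series" means these compounds.

This account follows one change made to the shared core of compound 1, whose structure is `Cc1ccccc1C(=O)Nc1nc(-c2ccccn2)cs1`. In an ADME assay on Vero cells (Chlorocebus sabaeus) for cytotoxicity, read by MTT assay, with a stated time of 72 h (a lower number here means that less compound is needed, a higher number that more compound is needed for the effect), compound 1 gives 6300 nM. Going by the values given here, compound 2, `O=C(Nc1nc(-c2ccccn2)cs1)c1cc(F)ccc1F`, is the only other compound with a number: in this assay compound 2 gives 3300 nM. The two numbers lie within the usual scatter of repeated measurements of each other, so neither compound can be set apart from the other on this evidence. Compound 3, `O=C(Nc1nc(-c2ccccn2)cs1)c1ccc(F)c(F)c1`, in this assay gives "not determined" (no result reported), so no result is reported for compound 3 here. Among the compounds with values here, none of the measured compounds differ from one another in a single place, so no matched step is available to show how large a change of one group tends to be here.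

Compound 4, `O=C(Nc1nc(-c2ccccn2)cs1)c1ccccn1`, differs from compound 1 by pyridin-2-yl in place of 2-methylphenyl on a carbonyl carbon. Within the data shown here, with no matched step to draw on, the expectation rests on the spread of the numbers already seen, which stay close together. The step from compound 1 to compound 4 is expected to be small, a 1.1-fold lower number from compound 1 to compound 4 (0.02 log units; within the scatter), in no particular direction and not beyond the scatter. Compound 4 is therefore estimated to give about 6000 nM in this assay, with a likely range from 2000 nM to 18000 nM.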

Compound 4, half-maximal effective concentration: 5400 nM
Estimate against measurement, compound 4: 1.1-fold (0.05 log units) above; low and high end bracket the measured number.
By their numbers in this assay, from the lowest: compounds 2, 4 and 1 (each within the scatter of the next).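

Going by these compounds alone, this is the first matched step, and it puts a number on the group held by the carbonyl carbon. In this assay, pyridin-2-yl in place of 2-methylphenyl gives a 1.2-fold lower number from compound 1 to compound 4 (0.07 log units; within the scatter) and so stays within the scatter, even though a carbon-only aromatic ring gives way to one with a ring nitrogen and the group gains a hydrogen-bond acceptor. At this position, then, this one exchange cannot be told apart from no difference on this read-out, and nothing measured here offers an explanation for that.

The compounds shown leave open whether a group of a different kind on this carbonyl carbon, such as an amine, a carboxylic acid or a longer alkyl chain, would give a step beyond the scatter. They also leave open where plain phenyl, with neither the methyl group nor the ring nitrogen, would fall, so the parts played by these two features cannot be separated.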